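Amine variation on the shared core, three limits so far

The source may report more compounds than this note shows. Statements on the series, on what has been measured and on what is new or still open speak of the compounds shown alone.

Compound 1 `O=C1C=C(NCc2ccccc2)C(=O)c2c1nc1n2[C@H]2OC[C@@H](O)[C@H]2OC1`: in a functional assay on ECa-109 cells for inhibition, with ECa-109 cell line (Homo sapiens) as the target, read by sulforhodamine B assay (a lower number here means a stronger inhibitor, a higher number a weaker inhibitor), compound 1 gives > 8000 nM, a limit of the assay.
Compound 2 `O=C1C=C(N2CCC2)C(=O)c2c1nc1n2[C@H]2OC[C@@H](O)[C@H]2OC1`: in this assay compound 2 gives > 16000 nM, also a limit.
Compound 3 `COc1ccc(NC2=CC(=O)c3nc4n(c3C2=O)[C@H]2OC[C@@H](O)[C@H]2OC4)cc1`: in this assay compound 3 gives > 4000 nM, again a limit.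

Compound 3 therefore stands at a limit, and the two other values are limits too, so no number places it within the set. The steps a step that the two limits leave unreadable from compound 1 to compound 3 and a step that the two limits leave unreadable from compound 2 to compound 3 are unreadable, as is a step that the two limits leave unreadable from compound 1 to compound 2.

Compound 4 `O=C1C=C(Nc2cccc(Cl)c2)C(=O)c2c1nc1n2[C@H]2OC[C@@H](O)[C@H]2OC1` differs from compound 3 by 3-chlorophenyl in place of 4-methoxyphenyl on an amine nitrogen. Among the measured compounds shown here, all three values sit at limits the limit of > 16000 nM in this assay, at which 1 of the 3 values shown sits, the limit of > 4000 nM in this assay, at which 1 of the 3 values shown sits (the limit of > 8000 nM in this assay, at which 1 of the 3 values shown sits), so no measured step gives a size or direction for this change; the only bearing is that no compound so far reaches a number. The step expected here is a step that the limit leaves unreadable from compound 3 to compound 4, most likely leaving the value again beyond the assay's reach. Compound 4 is estimated at 8000 nM, with a range from 2000 nM to 32000 nM.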

Compound 4, half-maximal inhibitory concentration: 4690 nM
Estimate against measurement, compound 4: 1.7-fold (0.23 log units) above; the range from low to high includes it.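

In this assay compound 4 is the only compound shown with a number rather than a limit, which gives (3-chlorophenyl)amino on the double-bonded ring carbon the first readable value. The change from azetidin-1-yl gives an at least 3.4-fold lower number from compound 2 to compound 4 (0.53 log units; beyond the scatter), while the change from benzyl on the amine nitrogen gives an at least 1.7-fold lower number from compound 1 to compound 4 (0.23 log units; that floor lies within the scatter). The step from compound 3 to compound 4 cannot be read, so the exchange of 4-methoxyphenyl for 3-chlorophenyl has no size.

The compounds shown leave open whether the chlorine alone goes with the measurable value; 4-chlorophenyl or 3-methoxyphenyl on the same amine nitrogen would bear on this.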